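Changing the ring on the cyclic amide nitrogen

A few compounds are considered here, and "the series" means these few. Any claim that something is new, unique, unknown or untested is made for them only; others in the source may bear on it.

Compound 1, `O=C(O)c1cccc(-c2ccc(/C=C3\S/C(=N\c4ccccc4)N(c4ccc(F)cc4)C3=O)o2)c1`: in an ADME assay on Vero cells (Chlorocebus sabaeus) for cytotoxicity (a higher number here means that more compound is tolerated, a lower number that less compound is tolerated), compound 1 gives > 200000 nM, which is a limit of the assay.
Compound 2, `O=C(O)c1cccc(-c2ccc(/C=C3\S/C(=N\c4ccccc4)N(c4ccc(F)cn4)C3=O)o2)c1`: in this assay compound 2 gives > 200000 nM, which is also a limit of the assay.

Compound 1 and compound 2 share the same core and differ only in the aromatic ring that hangs on the amide-type nitrogen in the five-membered ring. The step from compound 1 to compound 2 puts 5-fluoropyridin-2-yl in place of 4-fluorophenyl, and a step that the two limits leave unreadable from compound 1 to compound 2. Compound 2 therefore stands at the limit of > 200000 nM in this assay, at which 2 of the 2 values shown sit, without a number of its own.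

Compound 3, `O=C(O)c1cccc(-c2ccc(/C=C3\S/C(=N\c4ccccc4)N(c4cccnc4Cl)C3=O)o2)c1`, keeps everything else and differs from compound 2 by 2-chloropyridin-3-yl in place of 5-fluoropyridin-2-yl on an amide-type nitrogen in a ring. Among the measured compounds shown here, only one measured step bears on this change, and its size cannot be read. Since both measured compounds sit at the same limit, the step from compound 2 to compound 3 is expected to stay within the scatter, a number no higher from compound 2 to compound 3 (the limit leaves the size open). Compound 3 is expected to give about 200000 nM in this assay, most likely again as a limit, within a range from 100000 nM to 400000 nM.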

Compound 3, half-maximal cytotoxic concentration: > 200000 nM
Compound 3: only a limit was reported (the forecaster's own chance of this, stated with the estimate: 80%); the middle value lies on the limit itself.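

No step among compound 1, compound 2 and compound 3 can be read, since all three stand at one and the same limit: the limit of > 200000 nM in this assay, at which 3 of the 3 values shown sit.

The compounds shown leave open where in this assay any of them would reach its half-maximal cytotoxic concentration, and whether changing the ring on the amide-type nitrogen shifts that concentration at all.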